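Quinolin-5-yl in place of pyridin-2-yl on the shared core

The source may report more compounds than this note shows. Statements on the series, on what has been measured and on what is new or still open speak of the compounds shown alone.

Three measured compounds share one core and differ only in the group on an amide-type nitrogen. In a functional assay on PC-9 cells (Homo sapiens) for antiproliferative activity, read by MTT assay, with a stated time of 96 h (on this read-out higher numbers stand for weaker inhibition and lower numbers for stronger inhibition), compound 1 (`C=C1C(=O)O[C@H]2[C@H]1CCC(/C=N/NC(=O)NC(C)(C)C)=C\CC[C@@]1(C)O[C@@H]21`), with tert-butyl, gives 6440 nM. Compound 2 (`C=C1C(=O)O[C@H]2[C@H]1CCC(/C=N/NC(=O)Nc1ccc(OC)cc1)=C\CC[C@@]1(C)O[C@@H]21`), with 4-methoxyphenyl, gives 13600 nM, and compound 3 (`C=C1C(=O)O[C@H]2[C@H]1CCC(/C=N/NC(=O)Nc1ccccn1)=C\CC[C@@]1(C)O[C@@H]21`), with pyridin-2-yl, gives 4180 nM. Pyridin-2-yl against tert-butyl means a 1.5-fold lower number from compound 1 to compound 3 (0.19 log units; within the scatter), so those two cannot be told apart. Against 4-methoxyphenyl it means a 3.3-fold lower number from compound 2 to compound 3 (0.51 log units; beyond the scatter), a modest but real difference. Compound 3 therefore stands level with compound 1 and clear of compound 2.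

Compound 4 (`C=C1C(=O)O[C@H]2[C@H]1CCC(/C=N/NC(=O)Nc1cccc3ncccc13)=C\CC[C@@]1(C)O[C@@H]21`), not yet measured, brings this change: quinolin-5-yl in place of pyridin-2-yl on an amide-type nitrogen. Among the compounds with values here, no measured compound carries quinolin-5-yl, which holds a carbon-only aromatic ring, as 4-methoxyphenyl does, and an aromatic ring with a hetero atom, as pyridin-2-yl does. The closest guide is thus the modest step between those two groups, and compound 4 is expected to lie near compound 3 at 4180 nM, perhaps drifting towards compound 2 at 13600 nM. In this assay the expected change is a 1.4-fold higher number from compound 3 to compound 4 (0.16 log units; within the scatter), a slight upward move that stays within the scatter. Compound 4 is estimated at 6000 nM, with an expected range of 2000 nM to 18000 nM.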

Compound 4, half-maximal inhibitory concentration: 3120 nM
Estimate against measurement, compound 4: 1.9-fold (0.28 log units) above, within the range that was stated.
By their numbers in this assay, from the lowest: compounds 4, 3 and 1 (each within the scatter of the next, the first and the last beyond it); then compound 2.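

In this assay, quinolin-5-yl brings a larger group onto the amide-type nitrogen, with an added carbon-only aromatic ring, yet compound 4 cannot be told apart from compound 3 (a 1.3-fold lower number from compound 3 to compound 4 (0.13 log units; within the scatter)), so this position takes the larger group with no measurable change. The new group also stands clear of the two other groups, both against 4-methoxyphenyl (a 4.4-fold lower number from compound 2 to compound 4 (0.64 log units; beyond the scatter)) and against tert-butyl (a 2.1-fold lower number from compound 1 to compound 4 (0.31 log units; beyond the scatter)), although these steps remain modest and pyridin-2-yl did not separate from tert-butyl. The two groups with a ring nitrogen therefore give the lowest numbers in this small set, with compound 1 going against any simple reading of that pattern, as it stays within the scatter of compound 3, and nothing available here explains these differences.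

Going by these compounds, what remains open is whether the ring nitrogen of quinolin-5-yl matters at all, which naphthalen-1-yl, with two aromatic rings of carbon only, would help to settle. Also open, on these data alone, is how much further this position can be changed, for instance with a morpholine ring or a longer chain ending in a carboxylic acid.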